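This account rests on a few compounds, and the source may have more. Where it says the series, first, only, none or still open, it means among the compounds named here.

Working notes on the series.

Three compounds carry numbers in a functional assay on CHO cells for antagonist activity at metabotropic glutamate receptor 5 (Rattus norvegicus), read by calcium flux; a higher number here means a weaker inhibitor, a lower number a stronger inhibitor. Compound 1 `Cc1cccc(-c2cc3ncccc3cn2)c1` gives 1270 nM in this assay. Compound 2 `Cc1ccc(-c2cnc3cccnc3c2)cc1C` gives 12000 nM in this assay. Compound 3 `Cc1ccc2cnc(-c3ccccc3)cc2n1` returns only a limit in this assay, > 30000 nM, which is the limit of the assay and not a number; one of the three values shown sits there (the limit of > 30000 nM in this assay, at which 1 of the 3 values shown sits). On the numbers shown compound 3 therefore stands at the weak end, beyond any stated measurement, and no step between measured compounds that differ in a single place is available within this set.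

The step to compound 4 `COc1cccc(-c2cc3nc(C)ccc3cn2)c1` is one change: methoxy in place of hydrogen on an aromatic carbon, on an aromatic carbon of a six-membered aromatic ring of carbon only, meta to a large group. Among the measured compounds shown here, no measured pair shows the effect of this change here, so the expected step is taken as a moderate gain in potency, with wide uncertainty; the step from compound 3 to compound 4 is estimated as an at least 3.3-fold lower number from compound 3 to compound 4 (0.52 log units; beyond the scatter). For compound 4 the expected value in this assay is estimated at 9000 nM, within a range of 2000 nM to 30000 nM.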

Compound 4, half-maximal inhibitory concentration: 7900 nM
Beside the measured number, compound 4's estimate is 1.1-fold (0.06 log units) above it, within the range that was stated.
By their numbers in this assay, from the lowest: compound 1; then compounds 4 and 2 (each within the scatter of the next). At a limit, above all of these: compound 3.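

Among the compounds shown here, this is the first step that can be read for a change in a single place: in this assay, methoxy in place of hydrogen on an aromatic carbon of a six-membered aromatic ring of carbon only, meta to a large group, gives an at least 3.7-fold lower number from compound 3 to compound 4 (0.57 log units; beyond the scatter). With methoxy at this place, compound 4 reads 7900 nM, which shows that this position accepts a group of this size. Compound 3 stands at a limit of the assay and not at a number, so the step gives only the smallest gain consistent with the data, not its full size, and the change brings the series from a limit to a measured number: the limit of > 30000 nM in this assay, at which 1 of the 4 values shown sits.

The compounds shown leave open whether methoxy would bring a similar step on the cores of compound 1 or compound 2, where no single-place pair exists. They also leave open how a hydroxyl, an ethoxy, a longer chain or an amine would read at the same place, and so whether the oxygen or the added carbon matters for the step.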